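The compounds below may be only part of what the source reports. "The series", "measured", "known", "first", "only" and "open" are said of these compounds alone.

Measured in a functional assay on HepG2 cells (Homo sapiens) for cytotoxicity, read by MTT assay; on this read-out higher numbers stand for weaker inhibition and lower numbers for stronger inhibition:
compound 1 `O=C1C=C(Nc2ccc(OC(F)(F)F)cc2)C(=O)c2scnc21` — only a limit, > 100 ug/mL
compound 2 `O=C1C=C(Nc2ccc(Cl)cc2)C(=O)c2scnc21` — 16.4 ug/mL
compound 3 `O=C1C=C(Nc2cccc(F)c2)C(=O)c2scnc21` — only a limit, > 100 ug/mL

Compound 3 stands at the limit of > 100 ug/mL in this assay, at which 2 of the 3 values shown sit, so its place among the three is known only as a limit, not as a number. Compound 2 alone gives a number. The next compound is compound 4 `O=C1C=C(Nc2ccccc2)C(=O)c2scnc21`, reached by hydrogen in place of fluoro on an aromatic carbon. For the measured compounds named here, the one measured step, an at least 6.0-fold lower number from compound 1 to compound 2 (0.78 log units; beyond the scatter), replaces one group by another and does not bear directly on taking a fluoro away; no measured step covers that change. The step is expected to be small, an at least 1.2-fold lower number from compound 3 to compound 4 (0.09 log units; that floor lies within the scatter), with no direction forced beyond the scatter. Compound 4 is estimated at 80 ug/mL, between 25 ug/mL and 300 ug/mL.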

Compound 4, half-maximal inhibitory concentration: 14.7 ug/mL
Compound 4: middle estimate off by 5.4-fold (0.74 log units), on the high side, and the stated range ends above it.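

In this assay, hydrogen in place of fluoro gives an at least 6.8-fold lower number from compound 3 to compound 4 (0.83 log units; beyond the scatter), so taking away this fluoro, meta to a large group, is not a small change. Hydrogen in place of chloro gives a 1.1-fold lower number from compound 2 to compound 4 (0.05 log units; within the scatter), so chloro and hydrogen cannot be told apart here. Hydrogen in place of trifluoromethoxy gives an at least 6.8-fold lower number from compound 1 to compound 4 (0.83 log units; beyond the scatter), so fluoro and trifluoromethoxy go with a higher number than hydrogen, while chloro goes against that pattern.

The full size of the two larger steps stays open, as each starts from a limit: the limit of > 100 ug/mL in this assay, at which 2 of the 4 values shown sit.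

Going by these compounds, whether an amine or a carboxylic acid on this ring would shift the number is also open.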